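This account rests on a few compounds, and the source may have more. Where it says the series, first, only, none or still open, it means among the compounds named here.

The study follows a set of aryl ethers carrying a thiourea on a bicyclic nitrogen core, tested in an ADME assay on Huh-7 cells (Homo sapiens) for cytotoxicity; a higher number here means that more compound is tolerated, a lower number that less compound is tolerated. Compound 1 `NC(=S)n1ccc2c(OCCCCCOc3ccc(Cl)cc3)cccc21` gives 24700 nM in this assay. Compound 2 `O=C(NC(=S)N1CCc2ccc(OCc3ccccc3)cc21)c1ccccc1` gives 43800 nM in this assay. Compound 3 `O=C(NC(=S)N1CCc2c(OCCCCCOc3ccc(Cl)cc3)cccc21)c1ccc(Br)cc1` gives 29100 nM in this assay. Compound 3 stands second highest of the three numbers; its value and that of compound 1 lie within the scatter of each other, as do its value and that of compound 2, so no ordering among these three can be read from them.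

Compound 4 `O=C(NC(=S)N1CCc2c(OCCCCCOc3ccc(Cl)cc3)cccc21)C1CCCC1` differs from compound 3 in one place: cyclopentyl in place of 4-bromophenyl on a carbonyl carbon. For the measured compounds named here, no step between two measured compounds covers this exchange, so no measured precedent exists for its size. The three measured values cluster closely, and a change of this kind is expected to move the number little, if at all, beyond the scatter, in no particular direction. The step from compound 3 to compound 4 is therefore estimated as a 1.0-fold higher number from compound 3 to compound 4 (0.01 log units; within the scatter). For compound 4 in this assay the expected value is 30000 nM, with a range from 12000 nM to 70000 nM.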

Compound 4, half-maximal cytotoxic concentration: > 50000 nM
Compound 4: no number, only a limit (the forecaster's own chance of this, stated with the estimate: 15%); middle value at least 1.6-fold (0.22 log units) from the limit.
By their numbers in this assay, from the lowest: compounds 1, 3 and 2 (each within the scatter of the next). At a limit, above all of these: compound 4.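

In this assay compound 4 gives > 50000 nM, which is a limit of the assay and not a number: the limit of > 50000 nM in this assay, at which 1 of the 4 values shown sits. For the compounds shown here, the exchange of 4-bromophenyl for cyclopentyl on a carbonyl carbon, the first change that can be read at this place, comes to an at least 1.7-fold higher number from compound 3 to compound 4 (0.23 log units; that floor lies within the scatter). Going by these compounds alone, a non-aromatic ring in place of the brominated aromatic ring therefore gives no sign that less compound is tolerated, though the true size of the step stays unknown and its floor alone does not separate it from the scatter.

Going by these compounds, whether the bromine or the aromatic ring counts here stays open, since this step changes both at once; a plain phenyl on the same carbonyl carbon would separate the two. On these data alone, how an amine or a carboxylic acid at this place would read also stays open.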